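The compounds below may be only part of what the source reports. "The series", "measured", "known", "first", "only" and "open" are said of these compounds alone.

Compound 1 `Cc1cc(C)cc(S(=O)(=O)c2c(C(=O)NC(C)C(=O)NC(C)c3ccccc3)[nH]c3ccc(Cl)cc23)c1`, compound 2 `Cc1cc(C)cc(S(=O)(=O)c2c(C(=O)NCC(=O)NC(C)c3ccncc3)[nH]c3ccc(Cl)cc23)c1` and compound 3 `Cc1cc(C)cc(S(=O)(=O)c2c(C(=O)Nc3cc(C#N)ccn3)[nH]c3ccc(Cl)cc23)c1` share one core and differ in the group on the amide-type nitrogen. In an ADME assay on MT4 cells (Homo sapiens) for cytotoxicity, read by MTT assay (a lower number here means that less compound is tolerated, a higher number that more compound is tolerated), compound 1 gives 21700 nM. In this assay compound 2 gives 47000 nM. For compound 3 the this assay reports only a limit, > 53700 nM, so where compound 3 stands on the numbers shown cannot be pinned down, as recorded in the limit of > 53700 nM in this assay, at which 1 of the 3 values shown sits. Among the measured compounds shown here, the single measured step, an at least 1.1-fold higher number from compound 2 to compound 3 (0.05 log units; that floor lies within the scatter), did not leave the scatter. Compound 4 `Cc1cc(C)cc(S(=O)(=O)c2c(C(=O)NC(C)c3ccccc3F)[nH]c3ccc(Cl)cc23)c1` differs from compound 3 by 1-(2-fluorophenyl)ethyl in place of 4-cyanopyridin-2-yl on an amide-type nitrogen. For the measured compounds named here, no measured step covers this change, and compound 1 and compound 2 each gave a number while compound 3 gave only a limit, so the pointer is weak. Compound 4 is therefore expected in the this assay to give about 35000 nM, within a range from 12000 nM to 100000 nM. That estimate for compound 4 means a step of an at least 1.5-fold lower number from compound 3 to compound 4 (0.18 log units; that floor lies within the scatter), expected to stay within the scatter, with a fair chance that only a limit is reported again.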

Compound 4, half-maximal cytotoxic concentration: > 51500 nM
Compound 4 gave a limit, no number; the forecaster's own chance of this, stated with the estimate: 35%; middle value at least 1.4-fold (0.16 log units) from the limit.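

In this assay the change to 1-(2-fluorophenyl)ethyl on the amide-type nitrogen again yields a limit, not a number, for compound 4: the limit of > 51500 nM in this assay, at which 1 of the 4 values shown sits.

Compound 3 also stands at a limit, and the step between these two compounds cannot be read: the limit of > 53700 nM in this assay, at which 1 of the 4 values shown sits.

Among the compounds shown here, what compound 4 does add is a first step beyond the scatter, an at least 2.3-fold higher number from compound 1 to compound 4 (0.37 log units; beyond the scatter), while the other readable step, an at least 1.0-fold higher number from compound 2 to compound 4 (0.03 log units; that floor lies within the scatter), stays within the scatter.

On these data alone, the actual levels of compound 3 and compound 4 remain open, as does any ranking of 4-cyanopyridin-2-yl against 1-(2-fluorophenyl)ethyl. Also open, as far as these compounds go, is what an amine or a carboxylic acid on the amide-type nitrogen would give in this assay.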